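Replacing trifluoromethyl with methoxy: what to expect

A few compounds are considered here, and "the series" means these few. Any claim that something is new, unique, unknown or untested is made for them only; others in the source may bear on it.

Going by the values given here, in a functional assay on B16-F0 cells (Mus musculus) for inhibition, read by CCK-8 assay, with a stated time of 48 h (a lower number here means a stronger inhibitor, a higher number a weaker inhibitor), compound 1 (`COc1cc(-c2ccnc3cc(-c4ccc(F)cc4)nn23)cc(OC)c1OC`) gives 4540 nM and compound 2 (`COc1cc(-c2ccnc3cc(-c4ccc(C(F)(F)F)cc4)nn23)cc(OC)c1OC`) gives 1770 nM as the lower of the two numbers measured so far. Compound 3 (`COc1ccc(-c2cc3nccc(-c4cc(OC)c(OC)c(OC)c4)n3n2)cc1`) is still unmeasured and differs from compound 2 by one change (methoxy in place of trifluoromethyl on an aromatic carbon), methoxy in place of trifluoromethyl on an aromatic carbon. Among the compounds with values here, one measured step bears on it, trifluoromethyl in place of fluoro (a 2.6-fold lower number from compound 1 to compound 2 (0.41 log units; beyond the scatter)), which is modest but beyond the scatter. Within the data shown here, no methoxy compound has been measured yet, so that single step is a thin guide. Compound 2 sits at the low end at 1770 nM and so a modest move to a higher number in this assay is expected, perhaps no larger than the scatter. The estimated change is a 1.7-fold higher number from compound 2 to compound 3 (0.23 log units; within the scatter) in this forecast. For compound 3 the estimated value is 3000 nM with 1200 nM to 7500 nM as its expected range.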

Compound 3, half-maximal inhibitory concentration: 1410 nM
The estimate for compound 3 lay 2.1-fold (0.33 log units) above the measured number, and the stated range covers the measured number.
By their numbers in this assay, from the lowest: compounds 3 and 2 (each within the scatter of the next); then compound 1.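

In this assay, the swap gives a 1.3-fold lower number from compound 2 to compound 3 (0.10 log units; within the scatter), so trifluoromethyl and methoxy at this place on the ring cannot be told apart, even though the swap adds a hydrogen-bond acceptor and leaves fewer heavy atoms. Methoxy in place of fluoro gives a 3.2-fold lower number from compound 1 to compound 3 (0.51 log units; beyond the scatter), so two quite different groups now both separate from fluoro by more than the scatter, where before only trifluoromethyl had shown this. Nothing at hand explains why these groups read alike or why fluoro stands apart.

The compounds shown leave open how an amine, a carboxylic acid or a longer alkoxy chain would read at this place. They also leave open whether any group here can move the number by more than these modest steps, or whether the rest of the core matters more.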